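This account rests on a few compounds, and the source may have more. Where it says the series, first, only, none or still open, it means among the compounds named here.

Measured compounds in a functional assay on A549 cells (Homo sapiens) for inhibition, read by MTT assay, with a stated time of 48 h; on this read-out lower numbers stand for stronger inhibition and higher numbers for weaker inhibition:
compound 1 `CCC(=O)Nc1ccc(N2CCN(c3ccc(OC[C@@H]4CO[C@@](Cn5cncn5)(c5ccc(Cl)cc5Cl)O4)cc3)CC2)cc1`, giving 2550 nM
compound 2 `O=C(CCCc1ccccc1)Nc1ccc(N2CCN(c3ccc(OC[C@@H]4CO[C@@](Cn5cncn5)(c5ccc(Cl)cc5Cl)O4)cc3)CC2)cc1`, giving 3780 nM
compound 3 `O=C(Nc1ccc(N2CCN(c3ccc(OC[C@@H]4CO[C@@](Cn5cncn5)(c5ccc(Cl)cc5Cl)O4)cc3)CC2)cc1)c1ccco1`, giving 10500 nM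

Compound 3 stands highest of the three numbers: its nearest neighbour is compound 2, by a 2.8-fold higher number from compound 2 to compound 3 (0.44 log units; beyond the scatter), and its furthest is compound 1, by a 4.1-fold higher number from compound 1 to compound 3 (0.61 log units; beyond the scatter). The step from compound 1 to compound 2, a 1.5-fold higher number from compound 1 to compound 2 (0.17 log units; within the scatter), lies within the scatter.

Compound 4 `Cc1ccc(C(=O)Nc2ccc(N3CCN(c4ccc(OC[C@@H]5CO[C@@](Cn6cncn6)(c6ccc(Cl)cc6Cl)O5)cc4)CC3)cc2)o1` differs from compound 3 by methyl in place of hydrogen on an aromatic carbon, that is, furan-2-yl becomes 5-methylfuran-2-yl on the carbonyl carbon. None of the three measured steps touches a substituent on the aromatic ring of the amide: each exchanges the whole group on the carbonyl carbon, and those exchanges produced steps ranging from within the scatter to modest. Among the compounds with values here, the record therefore gives no direct precedent for this change. Compound 4 is thus expected to stay close to compound 3, with a 1.1-fold lower number from compound 3 to compound 4 (0.02 log units; within the scatter) as the expected step, and an estimated value of 10000 nM in this assay, within a range of 4000 nM to 25000 nM.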

Compound 4, half-maximal inhibitory concentration: 4750 nM
Compound 4: middle estimate off by 2.1-fold (0.32 log units), on the high side; the range from low to high includes it.
By their numbers in this assay, from the lowest: compounds 1, 2 and 4 (each within the scatter of the next); then compound 3.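

In this assay, within the data shown here, methyl in place of hydrogen on this aromatic carbon, next to the ring oxygen, is the first change made within the furan ring rather than to the whole group on the carbonyl carbon, and it gives a 2.2-fold lower number from compound 3 to compound 4 (0.34 log units; beyond the scatter), a modest step beyond the scatter. It also closes the separation seen for furan-2-yl: a 1.3-fold higher number from compound 2 to compound 4 (0.10 log units; within the scatter) and a 1.9-fold higher number from compound 1 to compound 4 (0.27 log units; within the scatter) both lie within the scatter, so 5-methylfuran-2-yl cannot be told apart here from 3-phenylpropyl or ethyl on the carbonyl carbon. Nothing available explains the step from hydrogen to methyl. As far as these compounds go, whether a chlorine or a methoxy group at this same carbon would give a similar step remains open. So does whether methyl would have the same effect on a thiophene ring in place of the furan.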